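A few compounds are considered here, and "the series" means these few. Any claim that something is new, unique, unknown or untested is made for them only; others in the source may bear on it.

Working notes on the series. Compound 1 `COc1ccc(NC(=O)c2cccc(/C=C3\CC(=O)N(c4ccccc4)C3=O)c2)cc1` is the reference here. In an ADME assay on SW480 cells (Homo sapiens) for cytotoxicity, read by MTT assay, with a stated time of 72 h (on this read-out higher numbers stand for weaker inhibition and lower numbers for stronger inhibition), compound 1 gives > 100000 nM, which is a limit of the assay and not a number, the point being (the limit of > 100000 nM in this assay, at which 1 of the 3 values shown sits). Compound 2 `COc1ccc(NC(=O)c2cccc(/C=C3\CC(=O)N(c4ccc(C)cc4)C3=O)c2)cc1` carries methyl in place of hydrogen on an aromatic carbon, and in this assay compound 2 gives 93000 nM; the step of an at least 1.0-fold lower number from compound 1 to compound 2 (0.03 log units; that floor lies within the scatter) therefore says little beyond the scatter. Compound 3 `CCCCCN1C(=O)C/C(=C\c2cccc(C(=O)Nc3cccc(CC)c3)c2)C1=O` sits elsewhere in the series and in this assay compound 3 gives 83300 nM, a number close to the others shown.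

The change to compound 4 `O=C(Nc1ccccc1)c1cccc(/C=C2\CC(=O)N(c3ccccc3)C2=O)c1` is hydrogen in place of methoxy on an aromatic carbon, on the amide side of the core. Going by the values given here, no measured step touches this position directly; the only measured step, that from compound 1 to compound 2, shows essentially no movement, and all values seen cluster near the top of the assay. Compound 4 is therefore expected to stay close to compound 1, with a number no higher from compound 1 to compound 4 (the limit leaves the size open) anticipated to be within the scatter. The estimate for compound 4 in this assay is 100000 nM, spanning 50000 nM to 200000 nM, with a fair chance that only a limit is reported.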

Compound 4, half-maximal inhibitory concentration: > 100000 nM
Compound 4 was reported as a limit; the forecaster's own chance of this, stated with the estimate: 55%; the middle value sits exactly at the limit.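

In this assay compound 4 gives > 100000 nM as a limit of the assay and not a number. Going by these compounds alone, compound 1 stands at the same limit, so no step between compound 1 and compound 4 can be read: the limit of > 100000 nM in this assay, at which 2 of the 4 values shown sit. The compounds shown leave open whether hydrogen in place of methoxy moves the value at all.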